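This account rests on a few compounds, and the source may have more. Where it says the series, first, only, none or still open, it means among the compounds named here.

Measured so far in an assay on isolated protein for inhibition of Polyunsaturated fatty acid 5-lipoxygenase (Homo sapiens), read by ELISA, with a stated time of 10 min; a higher number here means a weaker inhibitor, a lower number a stronger inhibitor:
compound 1 `CCCCCCCCCCCCCCCc1cc(O)cc(OC)c1O` gives 140 nM
compound 2 `CCCCCCCCCCCCCC1=CC(=O)C=C(OC)C1=O` gives 1050 nM

Compound 2 has the higher of the two numbers. The gap between compound 2 and compound 1 lies beyond the scatter of repeated runs, and compound 2 is the weaker inhibitor of the pair. Compound 3 `CCCCCCCCCCCCCCCC1=CC(=O)C=C(OC)C1=O` is not yet measured. It differs from compound 2 in one place: ethyl in place of hydrogen on a saturated chain carbon, ten or more bonds along the chain from a double-bonded ring carbon. Among the measured compounds shown here, no measured pair shows this change, so there is no step to lean on; a change at that place is expected to move the number little, most likely within the scatter, in no firm direction. The expected step from compound 2 to compound 3 is a 1.2-fold lower number from compound 2 to compound 3 (0.07 log units; within the scatter). Compound 3 is therefore estimated at 900 nM, between 400 nM and 2000 nM.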

Compound 3, half-maximal inhibitory concentration: 790 nM
The estimate for compound 3 lay 1.1-fold (0.06 log units) above the measured number; low and high end bracket the measured number.
By their numbers in this assay, from the lowest: compound 1; then compounds 3 and 2 (each within the scatter of the next).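

In this assay ethyl in place of hydrogen on a saturated chain carbon, ten or more bonds along the chain from a double-bonded ring carbon, gives a 1.3-fold lower number from compound 2 to compound 3 (0.12 log units; within the scatter) and so does not separate the two compounds. Among the compounds shown here, this is the first view of a change at this far point on the chain, and here the extra carbons leave the reading within the scatter of repeat runs. Still open, from the compounds shown here alone, is whether a longer chain, or an amine or a carboxylic acid at this place, would behave the same way. No measurement given here accounts for this result.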